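This account rests on a few compounds, and the source may have more. Where it says the series, first, only, none or still open, it means among the compounds named here.

Three compounds share one core. In a functional assay on HeLa cells (Homo sapiens) for cytotoxicity, read by neutral red uptake, with a stated time of 3 days (on this read-out higher numbers stand for weaker inhibition and lower numbers for stronger inhibition), compound 1 `Nc1ccc(-c2cc(=O)c3c(N)c(F)c(Br)c(F)c3o2)cc1F` gives only a limit, > 100000 nM. Compound 2 `Nc1ccc(-c2cc(=O)c3c(N)c(F)c(O)c(F)c3o2)cc1F` likewise gives only a limit in this assay, > 100000 nM. Going by the values given here, compound 3 `Nc1ccc(-c2cc(=O)c3c(N)c(F)c(CO)c(F)c3o2)cc1F` is the only compound with a number, 24000 nM in this assay. The two readable steps are an at least 4.1-fold lower number from compound 1 to compound 3 (0.61 log units; beyond the scatter) and an at least 4.1-fold lower number from compound 2 to compound 3 (0.61 log units; beyond the scatter); the step that the two limits leave unreadable from compound 1 to compound 2 cannot be sized because both values sit at the limit of > 100000 nM in this assay, at which 2 of the 3 values shown sit. Compound 4 `CN(C)CCCC(=O)OCc1c(F)c(N)c2c(=O)cc(-c3ccc(N)c(F)c3)oc2c1F` differs from compound 3 by (3-(dimethylamino)propyl)carbonyl in place of hydrogen on an oxygen on a saturated carbon. Among the compounds with values here, no measured step touches the oxygen on a saturated carbon, so the two readable steps give only a sense of scale; no change beyond the scatter is expected, and the estimated step is a 1.2-fold lower number from compound 3 to compound 4 (0.08 log units; within the scatter). Compound 4 is therefore expected to give about 20000 nM, between 6000 nM and 80000 nM.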

Compound 4, half-maximal inhibitory concentration: 4500 nM
For compound 4 the middle estimate is 4.4-fold (0.65 log units) above the measured one; the whole stated range lies above it.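

In this assay, going by these compounds alone, (3-(dimethylamino)propyl)carbonyl in place of hydrogen gives a 5.3-fold lower number from compound 3 to compound 4 (0.73 log units; beyond the scatter) and so shows that the oxygen on a saturated carbon, untouched by the earlier steps, is a place where a change can be read. Compared with the two compounds that lack the hydroxymethyl group, the new group gives an at least 22-fold lower number from compound 2 to compound 4 (1.34 log units; beyond the scatter) and an at least 22-fold lower number from compound 1 to compound 4 (1.34 log units; beyond the scatter) in the same read-out. Compound 1 and compound 2 each give a limit and not a number: the limit of > 100000 nM in this assay, at which 2 of the 4 values shown sit.

As far as these compounds go, it stays open whether the dimethylamino group or the carbonyl accounts for the step. From the compounds shown here alone, how an acetyl group, a longer chain or a carboxylic acid would read on the same oxygen also stays open.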